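Replacing a hydroxyazetidine with a methoxyoxetanylmethoxy group

This account rests on a few compounds, and the source may have more. Where it says the series, first, only, none or still open, it means among the compounds named here.

Measured compounds:
compound 1 `Cc1cc(COc2ccc(F)cc2)nc(-c2ccccn2)n1`, 631 nM
compound 2 `Cc1cc(COc2ccc(F)c(F)c2)nc(-c2ccccn2)n1`, 501 nM
compound 3 `OC1CN(c2cc(COc3ccc(F)c(F)c3F)nc(-c3ccccn3)n2)C1`, 3160 nM

In a functional assay on cells for antagonist activity at Free fatty acid receptor 1 (Homo sapiens), read by TR-FRET and inositol phosphate accumulation, with a stated time of 2 h (on this read-out higher numbers stand for weaker inhibition and lower numbers for stronger inhibition), compound 3 gives the highest of the three numbers. Its nearest neighbour is compound 1, and compound 2 lies further away; both gaps are beyond the scatter, so compound 3 is the weakest inhibitor of the three. Among the compounds with values here, the only single-point step among the measured compounds is a 1.3-fold lower number from compound 1 to compound 2 (0.10 log units; within the scatter), which concerns a fluorine on the distal aromatic ring and does not touch the position that changes here.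

Compound 4 `COC1(COc2cc(COc3ccc(F)c(F)c3F)nc(-c3ccccn3)n2)COC1` differs from compound 3 in one place: (3-methoxyoxetan-3-yl)methoxy in place of 3-hydroxyazetidin-1-yl on an aromatic carbon. Within the data shown here, no measured pair shows what such an exchange does in this assay, so no direction can be drawn from the data; the change only removes the single donor of compound 3 while keeping a four-membered ring with one hetero atom.

For compound 4 the expected result in this assay is therefore close to that of compound 3, with the step of a 1.3-fold lower number from compound 3 to compound 4 (0.10 log units; within the scatter) judged as none beyond the scatter but with wide uncertainty: an estimate of 2500 nM, ranging from 700 nM to 9000 nM.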

Compound 4, half-maximal inhibitory concentration: 501 nM
Compound 4: middle estimate off by 5.0-fold (0.70 log units), on the high side, outside the stated range (below it).
By their numbers in this assay, from the lowest: compounds 2, 4 and 1 (each within the scatter of the next); then compound 3.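

In this assay the exchange gives a 6.3-fold lower number from compound 3 to compound 4 (0.80 log units; beyond the scatter), so compound 4 inhibits more strongly than compound 3, and the number responds clearly to what sits on this aromatic carbon next to the ring nitrogen. Within the data shown here, the larger (3-methoxyoxetan-3-yl)methoxy group, with no hydrogen-bond donor, is therefore accepted here, whereas the one earlier step concerned only a fluoro on the distal aromatic ring. Nothing available explains why the number moves.

The exchange alters the attachment atom, the ring, the donor count and the size together, so this single step cannot show which of these matters. A 3-methoxyazetidin-1-yl group would separate the loss of the hydroxyl hydrogen from the change of ring, and a simple methoxy group would show how much of the (3-methoxyoxetan-3-yl)methoxy group is needed at this position.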